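The compounds below may be only part of what the source reports. "The series", "measured", "known", "first", "only" and "open" are said of these compounds alone.

Compound 1 `CC(=O)NC1=C(C#N)C(c2ccc(F)cc2)C2=C(CC(C)(C)CC2=O)N1c1ccc(S(N)(=O)=O)cc1`, compound 2 `CCO/C=N/C1=C(C#N)C(c2ccc(F)cc2)C2=C(CC(C)(C)CC2=O)N1c1ccc(S(N)(=O)=O)cc1` and compound 3 `CCNC(=S)NC1=C(C#N)C(c2ccc(F)cc2)C2=C(CC(C)(C)CC2=O)N1c1ccc(S(N)(=O)=O)cc1` share one core. In a functional assay on MCF7 cells (Homo sapiens) for cytotoxicity, read by sulforhodamine B assay, with a stated time of 48 h (a higher number here means a weaker inhibitor, a lower number a stronger inhibitor), compound 1 gives 85900 nM, and compound 2 gives 67300 nM. For compound 3 the reading is a limit of this assay, > 100000 nM, so where compound 3 stands is known only as that limit, (the limit of > 100000 nM in this assay, at which 1 of the 3 values shown sits). The step to compound 4 `CC(=O)CC(=O)NC1=C(C#N)C(c2ccc(F)cc2)C2=C(CC(C)(C)CC2=O)N1c1ccc(S(N)(=O)=O)cc1` is a group of 6 heavy atoms (4 carbon, 2 oxygen; no ring) in place of a group of 5 heavy atoms (3 carbon, 1 nitrogen, 1 sulfur; no ring), on an amine nitrogen. The measured steps that touch the same position stayed small: an at least 1.1-fold higher number from compound 1 to compound 3 (0.06 log units; that floor lies within the scatter) and an at least 1.4-fold higher number from compound 2 to compound 3 (0.17 log units; that floor lies within the scatter), and likewise a 1.3-fold lower number from compound 1 to compound 2 (0.11 log units; within the scatter). None of them left the scatter, so for compound 4 no step beyond the scatter is expected in this assay. Compound 4 is therefore estimated at 90000 nM, within 45000 nM to 200000 nM, which is expected to mean an at least 1.1-fold lower number from compound 3 to compound 4 (0.04 log units; that floor lies within the scatter).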

Compound 4, half-maximal inhibitory concentration: > 100000 nM
Compound 4 was reported as a limit (the forecaster's own chance of this, stated with the estimate: 40%); at least 1.1-fold (0.04 log units) between middle value and limit.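

With compound 4, a second group on the amine nitrogen, (2-oxopropyl)carbonyl, reaches a limit in this assay, and no cause for this can be read from the data: the limit of > 100000 nM in this assay, at which 2 of the 4 values shown sit.

The readable steps are only floors within the scatter: an at least 1.4-fold higher number from compound 2 to compound 4 (0.17 log units; that floor lies within the scatter) and an at least 1.1-fold higher number from compound 1 to compound 4 (0.06 log units; that floor lies within the scatter). The step between the two limits cannot be read.

On these data alone, how far compound 3 and compound 4 lie past that limit stays open. So does whether a chain ending in an amine or a carboxylic acid on this nitrogen would give a reading beyond the scatter.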